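The source may report more compounds than this note shows. Statements on the series, on what has been measured and on what is new or still open speak of the compounds shown alone.

In a functional assay on HeLa cells (Homo sapiens) for inhibition, with a stated time of 72 h (on this read-out higher numbers stand for weaker inhibition and lower numbers for stronger inhibition), compound 1 `NC1CCC(Nc2nc(NCc3ccc(Br)cc3)c3ncn(C4CCCC4)c3n2)CC1` gives 1510 nM while compound 2 `NC1CCC(Nc2nc(NCc3ccc(-c4ccco4)nc3)c3ncn(C4CCCC4)c3n2)CC1` gives 30 nM as the lower of the two numbers, which makes it the stronger inhibitor of this pair. Compound 3 `NC1CCC(Nc2nc(NCc3ccc(-c4ccsc4)nc3)c3ncn(C4CCCC4)c3n2)CC1` differs from compound 2 in one place only. The change is thiophen-3-yl in place of furan-2-yl on an aromatic carbon and in words it is thiophen-3-yl in place of furan-2-yl on an aromatic carbon, next to the ring nitrogen of a six-membered aromatic ring with 1 nitrogen.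

Among the measured compounds shown here, only one measured step bears on this: a 50-fold lower number from compound 1 to compound 2 (1.70 log units; beyond the scatter) when 6-(furan-2-yl)pyridin-3-yl replaced 4-bromophenyl. For the measured compounds named here, that step was large, but it exchanged the whole group, whereas the new change swaps only one five-membered aromatic ring for another. Going by the values given here, no measured pair isolates that outer ring, so the direction stays open and the size is a judgement. The expected result is a 1.2-fold higher number from compound 2 to compound 3 (0.07 log units; within the scatter) as a best guess, with little or no real change. For compound 3 the estimated value in this assay is 35 nM with an expected range from 12 nM to 100 nM on that read-out.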

Compound 3, half-maximal inhibitory concentration: 75 nM
Compound 3: middle estimate off by 2.1-fold (0.33 log units), on the low side; the range from low to high includes it.
By their numbers in this assay, from the lowest: compound 2; then compound 3; then compound 1.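

In this assay the exchange of furan-2-yl for thiophen-3-yl gives a 2.5-fold higher number from compound 2 to compound 3 (0.40 log units; beyond the scatter) even though both groups are five-membered aromatic rings with matching counts of heavy atoms and hydrogen-bond acceptors, so this carbon of the six-membered aromatic ring with 1 nitrogen responds to more than those counts. The large gain over 4-bromophenyl is still there with the new outer ring, as a 20-fold lower number from compound 1 to compound 3 (1.30 log units; beyond the scatter) shows, so it does not depend on furan-2-yl alone. No supporting measurement is available to explain the difference between the two outer rings.

The exchange alters both the ring hetero atom, oxygen to sulfur, and the point at which the ring is attached, and a furan-3-yl or thiophen-2-yl group at this place would help to tell those two changes apart. On these data alone, it also remains open how much of the gain over 4-bromophenyl comes from the ring nitrogen and how much from the outer ring, a question that a 4-(furan-2-yl)phenyl group could address.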